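The compounds below may be only part of what the source reports. "The series", "measured", "known", "first", "only" and "open" are said of these compounds alone.

In a functional assay on NCI-H727 cells (Homo sapiens) for antiproliferative activity, with a stated time of 48 h (on this read-out higher numbers stand for weaker inhibition and lower numbers for stronger inhibition), compound 1 `CCN(CC)c1ccc(-c2cccc(OC)c2)nn1` gives > 25000 nM, which is a limit of the assay and not a number. Compound 2 `CC(=O)c1ccc(-c2ccc(N3CCCC3)nn2)cc1` gives > 25000 nM, again a limit. Compound 3 `COC(=O)c1cccc(-c2ccc(-n3cccc3)nn2)c1` gives > 25000 nM, also a limit. The whole set so far comes down to the limit of > 25000 nM in this assay, at which 3 of the 3 values shown sit, so compound 1 has no exact position. Compound 4 `CCN(CC)c1ccc(-c2cccc(C(F)(F)F)c2)nn1` carries trifluoromethyl in place of methoxy on an aromatic carbon of compound 1, (trifluoromethyl in place of methoxy on an aromatic carbon). For the measured compounds named here, no measured pair shows what such a swap does, so in this assay the expected a number no higher from compound 1 to compound 4 (the limit leaves the size open) is none beyond the scatter, in either direction. The limit of compound 1, > 25000 nM, is the only anchor for that expectation. Compound 4 is estimated at 25000 nM, with an expected range from 10000 nM to 50000 nM.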

Compound 4, half-maximal inhibitory concentration: > 25000 nM
Compound 4: only a limit was reported; the forecaster's own chance of this, stated with the estimate: 80%; the middle value lies on the limit itself.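

For the compounds shown here, compound 1 and compound 4 both give a limit rather than a number, so no step between them can be read. The compounds shown leave open which structural change, if any, would bring a measurable value, as all share one result: the limit of > 25000 nM in this assay, at which 4 of the 4 values shown sit.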